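Iodo for cyano on the fused thiophene of compound 3

The source may hold more compounds than are shown below. What is called first, only, known or untested is meant among the compounds shown, and "the series" means these compounds.

Measured so far:
- compound 1, `CC#C[C@@H](Cc1nnn[nH]1)c1ccc(OCc2cc(C)c3scc(-c4ccccc4C)c3c2)cc1`: 213 nM
- compound 2, `CC#C[C@@H](Cc1nnn[nH]1)c1ccc(OCc2ccc3scc(-c4ccc(OCCC(C)(C)O)cc4C)c3c2)cc1`: 4 nM
- compound 3, `CC#C[C@@H](Cc1nnn[nH]1)c1ccc(OCc2ccc3sc(C#N)c(-c4ccccc4C)c3c2)cc1`: 19 nM

In a functional assay on cells for agonist activity at Free fatty acid receptor 1 (Rattus norvegicus), read by FLIPR and calcium flux (on this read-out lower numbers stand for an effect already at smaller amounts and higher numbers for an effect only at larger amounts of compound), compound 3 gives 19 nM, the second highest of the three numbers. Its nearest neighbour is compound 2 with 4 nM, a lower number beyond the scatter; furthest away is compound 1 with 213 nM, a higher number beyond the scatter. Among the measured compounds shown here, no two of the measured compounds differ in a single place, so no measured step guides the change at hand.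

Compound 4, `CC#C[C@@H](Cc1nnn[nH]1)c1ccc(OCc2ccc3sc(I)c(-c4ccccc4C)c3c2)cc1`, differs from compound 3 in one place: iodo in place of cyano on an aromatic carbon. Nothing measured here speaks to an iodo group at that position. The account therefore treats the step as uncertain and expects, for compound 4 in this assay, a modest move toward higher numbers, a 1.6-fold higher number from compound 3 to compound 4 (0.20 log units; within the scatter), one that may well stay within the scatter. Compound 4 is accordingly estimated at 30 nM, with a range from 8 nM to 120 nM.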

Compound 4, half-maximal effective concentration: 33 nM
The estimate for compound 4 lay 1.1-fold (0.04 log units) below the measured number; the range from low to high includes it.
By their numbers in this assay, from the lowest: compound 2; then compounds 3 and 4 (each within the scatter of the next); then compound 1.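

Among the compounds shown, this is the only change made in one place, and it concerns the aromatic carbon next to the ring sulfur. In this assay, iodo in place of cyano gives a 1.7-fold higher number from compound 3 to compound 4 (0.24 log units; within the scatter), so this assay does not separate the two groups at this position, even though the cyano counts one hydrogen-bond acceptor and a triple bond and the iodo counts neither. Nothing available explains why the two groups read alike here.

The compounds shown leave open how an amine, a carboxylic acid or a methyl group would read on this carbon, and how a plain hydrogen there would compare in a one-place step. Also open, on these data alone, is how either group would read alongside the longer chain that compound 2 carries.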